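The source may report more compounds than this note shows. Statements on the series, on what has been measured and on what is new or still open speak of the compounds shown alone.

Measured so far in a functional assay on HT-29 cells (Homo sapiens) for cytotoxicity, read by sulforhodamine B assay, with a stated time of 48 h; on this read-out higher numbers stand for weaker inhibition and lower numbers for stronger inhibition:
compound 1 `Cc1ccccc1OS(=O)(=O)c1cccc(NC(=O)NCCCCl)c1`, 21000 nM
compound 2 `O=C(NCCCCl)Nc1cccc(S(=O)(=O)Oc2ccc(O)cc2)c1`, 51000 nM
compound 3 `Cc1ccccc1OS(=O)(=O)c1ccc(NC(=O)NCCCCl)cc1`, 26000 nM

Among these three numbers compound 3 gives the second highest. Compound 1 and compound 3 lie within the scatter of each other, and compound 2 and compound 3 lie within it as well, so no order among them can be claimed on this read-out. Among the compounds with values here, the one step that reaches beyond the scatter is a 2.4-fold higher number from compound 1 to compound 2 (0.39 log units; beyond the scatter), and it concerns an exchange of the whole group on the sulfonate oxygen.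

Compound 4 `CCCc1ccccc1OS(=O)(=O)c1ccc(NC(=O)NCCCCl)cc1` differs from compound 3 by ethyl in place of hydrogen on a saturated chain carbon bound to an aromatic carbon. Within the data shown here, no measured pair shows a change of this kind: the single counted step swaps one group on the oxygen for a different one and carries no information on the growth of a methyl into a propyl on the same position. All three measured numbers sit in a narrow band, and the series gives no ground for a move out of that band.

With nothing bearing directly on the change, compound 4 is expected to show a step of a 1.3-fold lower number from compound 3 to compound 4 (0.11 log units; within the scatter), within the scatter. Compound 4 is therefore estimated at 20000 nM in this assay, with a range from 8000 nM to 50000 nM.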

Compound 4, half-maximal inhibitory concentration: 13000 nM
The estimate for compound 4 lay 1.5-fold (0.19 log units) above the measured number; low and high end bracket the measured number.
By their numbers in this assay, from the lowest: compounds 4, 1, 3 and 2 (each within the scatter of the next, the first and the last beyond it).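

In this assay, the growth of methyl to propyl in the 2-methylphenyl group, with ethyl in place of hydrogen on a saturated chain carbon bound to an aromatic carbon, gives a 2.0-fold lower number from compound 3 to compound 4 (0.30 log units; within the scatter). Within the data shown here, this is the first step that keeps the group on the sulfonate oxygen and alters only its chain, whereas the earlier step replaced one group on that oxygen with another; compound 3 and compound 4 cannot be ordered on this read-out, so the two added carbons produce no step beyond the scatter here. No measurement at hand bears on the origin of this result.

On these data alone, whether a longer chain such as butyl or pentyl, a branched isopropyl group, or an amine or a carboxylic acid at the end of the propyl chain would give a step beyond the scatter remains open. Also open, as far as these compounds go, is whether 2-propylphenyl would give a comparable step on the core of compound 1, where the same 2-methylphenyl group is present.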